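The source may report more compounds than this note shows. Statements on the series, on what has been measured and on what is new or still open speak of the compounds shown alone.

Compound 1 `CS(=O)(=O)c1ccc(-c2cnc3[nH]cc(-c4nnc(-c5ccccc5)o4)c(=O)c3c2)cc1` gives 8.17% in a functional assay on A549 cells (Homo sapiens) for inhibition, read by MTT assay, with a stated time of 24 h, tested at 5 uM; a lower number here means less inhibition of growth, a higher number more inhibition of growth at the concentration tested.
Compound 2 `CS(=O)(=O)c1ccc(-c2cnc3[nH]cc(-c4nnc(-c5ccc(Cl)cc5)o4)c(=O)c3c2)cc1` gives 23.8% in this assay.
Compound 3 `N#Cc1ccc(-c2cnc3[nH]cc(-c4nnc(-c5ccc(Cl)cc5)o4)c(=O)c3c2)cc1` gives 7.6% in this assay.

Compound 3 stands lowest of the three numbers shown, though its gap to compound 1 lies within the scatter; only compound 2 is set apart from it, by a number 16.2 percentage points lower from compound 2 to compound 3 (beyond the scatter). The unmeasured compound 4 `O=c1c(-c2nnc(-c3ccc(Cl)cc3)o2)c[nH]c2ncc(-c3ccccc3)cc12` differs from compound 3 by hydrogen in place of cyano on an aromatic carbon.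

For the measured compounds named here, of the two measured steps, the one from compound 2 to compound 3 touches the same aromatic carbon and is the one that bears on this change; it read a number 16.2 percentage points lower from compound 2 to compound 3 (beyond the scatter). The step from compound 1 to compound 2, a number 15.6 percentage points higher from compound 1 to compound 2 (beyond the scatter), concerns the chloro position and says little here. Going by the values given here, no measured pair shows a cyano removed to hydrogen, so the expectation rests on compound 3 and compound 1 both sitting low. Compound 4 is therefore expected to stay near compound 3, with a step of a number 2.4 percentage points higher from compound 3 to compound 4 (within the scatter) not beyond the scatter. The estimate for compound 4 is 10%, between 0% and 25%.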

Compound 4, percent growth inhibition at one concentration: 1.44%
The estimate for compound 4 lay 8.6 percentage points above the measured number; the measured number falls inside the stated range.
By their numbers in this assay, from the lowest: compounds 4, 3 and 1 (each within the scatter of the next); then compound 2.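

On the aromatic carbon para to a large group, hydrogen in place of cyano gives a number 6.2 percentage points lower from compound 3 to compound 4 (within the scatter) in this assay, so the change from 4-cyanophenyl to phenyl makes no readable difference here. Hydrogen in place of methylsulfonyl gives a number 22.4 percentage points lower from compound 2 to compound 4 (beyond the scatter) and, with the chloro group held constant, this sets compound 2 apart from both compound 3 and compound 4, so among these three groups only methylsulfonyl stands out at this position. Nothing shown here explains this difference.

As far as these compounds go, it remains open whether an amine, a carboxylic acid or a sulfonamide on this carbon would match or exceed methylsulfonyl. The compounds shown also leave open whether the match between cyano and hydrogen would hold without the chloro group on the other phenyl ring.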